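Ring-nitrogen acylation in a cyclohexyl ether sulfonamide series

This account rests on a few compounds, and the source may have more. Where it says the series, first, only, none or still open, it means among the compounds named here.

Measured so far:
compound 1 `CC(=O)N1CCC[C@H](NS(=O)(=O)C(C)C)[C@@H]1CO[C@H]1CC[C@@H](C(C)C)CC1` — in a functional assay on CHO-K1 cells for agonist activity at Orexin/Hypocretin receptor type 1 (Homo sapiens), read by FLIPR and calcium flux (on this read-out higher numbers stand for an effect only at larger amounts of compound and lower numbers for an effect already at smaller amounts), compound 1 gives > 100000 nM, a limit of the assay
compound 2 `CC(=O)N1CCC[C@H](NS(C)(=O)=O)[C@@H]1CO[C@H]1CC[C@@H](c2ccccc2)CC1` — in this assay compound 2 gives > 100000 nM; > 100000 nM; > 100000 nM (3 entries), limits of the assay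
compound 3 `CS(=O)(=O)N[C@H]1CCCN[C@H]1CO[C@H]1CC[C@@H](c2ccccc2)CC1` — in this assay compound 3 gives > 100000 nM, a limit of the assay

Compound 3 stands only at a limit, with no number of its own; the other values shown are limits as well, so no order among the three can be read. (the limit of > 100000 nM in this assay, at which 2 of the 3 values shown sit).

Compound 4 `CCC(=O)N1CCC[C@H](NS(C)(=O)=O)[C@@H]1CO[C@H]1CC[C@@H](c2ccccc2)CC1` differs from compound 3 by propanoyl in place of hydrogen on an amine nitrogen in a ring. Within the data shown here, no step between measured compounds exists to size this change. Compound 2 also carries an acyl group on the ring amine nitrogen and sits at the limit. For the step from compound 3 to compound 4 no shift beyond the scatter is expected, the estimated step being a step that the limit leaves unreadable from compound 3 to compound 4. Compound 4 is expected at 150000 nM, in a range from 50000 nM to 500000 nM, most likely reported again only as a limit.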

Compound 4, half-maximal effective concentration: > 100000 nM
Compound 4 gave a limit, no number (the forecaster's own chance of this, stated with the estimate: 85%); the middle value does not contradict the limit.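

Compound 3 and compound 4 both stand only at a limit, so no step can be read for propanoyl in place of hydrogen in this assay: the limit of > 100000 nM in this assay, at which 3 of the 4 values shown sit.

The compounds shown leave open whether any change to the shared core yields a measurable value.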